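Methyl for Isopropyl on the Amine: Stability Expectation

The compounds below may be only part of what the source reports. "The series", "measured", "known", "first", "only" and "open" are said of these compounds alone.

Three compounds have been measured in an ADME assay on microsomes from liver (Mus musculus) for metabolic stability, read by LC-MS, with a stated time of 10 min; a higher number here means that more of the compound is left, a lower number that less of the compound is left:

- compound 1, `CN(C[C@H]1Cc2c(cccc2N2CCN3CCC[C@H]3C2)CN1)[C@H]1CCCc2cccnc21`, gives 40.1%
- compound 2, `CN(C[C@H]1Cc2c(cccc2N2CCN3CCC[C@@H]3C2)CN1)[C@H]1CCCc2cccnc21`, gives 36.7%
- compound 3, `CC(C)N(C[C@H]1Cc2c(cccc2N2CCNCC2)CN1)[C@H]1CCCc2cccnc21`, gives 91%

Compound 3 stands highest of the three numbers in this assay. Compound 1 comes nearest and compound 2 furthest, and both gaps lie beyond the scatter. Among the compounds with values here, the only measured step between compounds that differ in one place is a number 3.4 percentage points lower from compound 1 to compound 2 (within the scatter); it is within the scatter, and the two compounds share everything except (the fact that compounds 1 and 2 differ only in the configuration as drawn).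

Compound 4, `CN(C[C@H]1Cc2c(cccc2N2CCNCC2)CN1)[C@H]1CCCc2cccnc21`, is not yet measured. Against compound 3 the change is methyl in place of isopropyl on an amine nitrogen. Within the data shown here, no measured step swaps methyl for isopropyl on that nitrogen, so none bears directly on it. Compounds 1 and 2 carry a methyl at that place, but they also differ from compound 4 on the aryl nitrogen, so their numbers can only be shown beside it, not read as a step. Compound 1 gives 40.1% in this assay and compound 2 gives 36.7%.

With the step untested, a fall from compound 3 is expected but of uncertain size, a number 26 percentage points lower from compound 3 to compound 4 (beyond the scatter). Compound 4 is estimated at 65%, with a range from 35% to 92%.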

Compound 4, percent of the compound remaining: 19.9%
Beside the measured number, compound 4's estimate is 45.1 percentage points above it, outside the stated range (below it).
By their numbers in this assay, from the lowest: compound 4; then compounds 2 and 1 (each within the scatter of the next); then compound 3.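

In this assay, within the data shown here, the change from isopropyl to methyl on this amine nitrogen, whose other neighbours are a saturated chain carbon and a saturated ring carbon, can now be read directly, and it is the only difference in the step: a number 71.1 percentage points lower from compound 3 to compound 4 (beyond the scatter), so this one position has a large effect on how much compound is left. With methyl kept on that nitrogen, the group on the aromatic carbon also counts, though less: a number 16.8 percentage points lower from compound 2 to compound 4 (beyond the scatter) and a number 20.2 percentage points lower from compound 1 to compound 4 (beyond the scatter), where the group of 6 heavy atoms with one six-membered ring replaces the group of 9 heavy atoms that carries a further five-membered ring. Nothing known about these compounds gives a reason for either change.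

Only isopropyl and methyl are shown on this nitrogen, so it remains open where an ethyl or a cyclopropyl group, or a plain hydrogen, would fall. As far as these compounds go, it also remains open whether isopropyl would have a similar effect in a compound carrying the group of 9 heavy atoms on the aromatic carbon.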